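Cytotoxicity series on shared core: amide to acid

The source may report more compounds than this note shows. Statements on the series, on what has been measured and on what is new or still open speak of the compounds shown alone.

Measured so far in a functional assay on HeLa cells (Homo sapiens) for cytotoxicity, read by MTT assay, with a stated time of 24 h; on this read-out higher numbers stand for weaker inhibition and lower numbers for stronger inhibition:
- compound 1, `C=CC1=C(C(=O)Nc2ccc(C)cc2)C(c2ccc(F)cc2)OC1`: > 100000 nM, a limit of the assay
- compound 2, `C=CC1=C(C(=O)Nc2cccc(C)c2)C(c2ccc(F)cc2)OC1`: "not active" (no number reported), no number reported
- compound 3, `C=CC1=C(C(=O)NCC(C)C)C(c2ccc(F)cc2)OC1`: > 100000 nM, a limit of the assay

Compound 3 therefore stands on a limit only, not on a number. Compound 1 likewise sits on a limit. Compound 2 carries no number at all. Among the measured compounds shown here, the one step within the set, a step that the two limits leave unreadable from compound 1 to compound 3, is left unreadable by the two limits, and the limit of > 100000 nM in this assay, at which 2 of the 3 values shown sit, is the only firm point the series offers.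

Compound 4, `C=CC1=C(C(=O)O)C(c2ccc(F)cc2)OC1`, is the next entry. It differs from compound 3 by hydroxy in place of isobutylamino on a carbonyl carbon. For the measured compounds named here, no measured step speaks to this change: the only step available, the one from compound 1 to compound 3, has no readable size, and compound 2 adds no number. Nothing in the series points to any compound crossing into measurable inhibition, so no step beyond the scatter is expected in either direction.

Compound 4 is thus expected to remain at the limit, estimated at 100000 nM with a range from 30000 nM to 300000 nM. The expected step, a number no higher from compound 3 to compound 4 (the limit leaves the size open), is estimated as none beyond the scatter.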

Compound 4, half-maximal inhibitory concentration: 67400 nM
Estimate against measurement, compound 4: 1.5-fold (0.17 log units) above; low and high end bracket the measured number.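

Working notes: in this assay, compound 4 is the only compound in the series with a number rather than a limit or an entry without a value, so the carbonyl carbon is a place where a change of group can bring the read-out into measurable range. From the compounds shown here alone, replacing the amide with the acid gives an at least 1.4-fold lower number from compound 3 to compound 4 (0.17 log units; that floor lies within the scatter), and the same comparison with the aryl amide gives an at least 1.4-fold lower number from compound 1 to compound 4 (0.17 log units; that floor lies within the scatter); both sizes are floors, so these steps establish no difference beyond the scatter, and the true distance from either amide remains unknown. The step between the two amides cannot be read, and the amide end of each comparison rests on a limit: the limit of > 100000 nM in this assay, at which 2 of the 4 values shown sit.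

Going by these compounds, it remains open whether a methyl ester, a primary amide or a hydroxymethyl group on the same carbonyl-bearing ring carbon would also give a number, and so whether the carboxy group itself matters or only the loss of the substituted amide. The compounds shown also leave open whether a longer chain or a basic amine on the amide nitrogen would bring an amide off the limit.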